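Three Low Clearance Values and One Swap at the Sulfonyl

This account rests on a few compounds, and the source may have more. Where it says the series, first, only, none or still open, it means among the compounds named here.

Values measured in an ADME assay on microsomes from liver (Homo sapiens) for pharmacokinetics, read by LC-MS, with a stated time of 60 min, tested at 1 uM (a lower number here means slower removal, a higher number faster removal of the compound), are:

- Compound 1 `O=C(NCc1ccc(Cl)nc1)Nc1ccc(S(=O)(=O)c2ccccc2)cc1` gives 6 mL/min/kg
- Compound 2 `Nc1ccc(CNC(=O)Nc2ccc(S(=O)(=O)c3ccccc3)cc2)cn1` gives 5 mL/min/kg
- Compound 3 `O=C(NCc1cccnc1)Nc1ccc(S(=O)(=O)N2CC3(COC3)C2)cc1` gives 7 mL/min/kg

Compound 3 lies within the scatter of compounds 1 and 2, so these three values show no real order. Compound 4 `O=C(NCc1cccnc1)Nc1ccc(S(=O)(=O)N[C@H]2CC[C@H](O)CC2)cc1` differs from compound 3 in one place, on a sulfonyl sulfur, and a group of 8 heavy atoms (6 carbon, 1 nitrogen, 1 oxygen; one six-membered non-aromatic ring of carbon only) in place of a group of 7 heavy atoms (5 carbon, 1 nitrogen, 1 oxygen; 2 four-membered non-aromatic rings with 1 hetero atom each), on a sulfonyl sulfur describes that change. For the measured compounds named here, the one measured step (a 1.2-fold lower number from compound 1 to compound 2 (0.08 log units; within the scatter)) is on an aromatic carbon, not on the sulfonyl sulfur, so it offers only weak guidance. With compound 3 at 7 mL/min/kg as the starting point, no change beyond the scatter is expected in this assay. The expected step is a 1.1-fold higher number from compound 3 to compound 4 (0.06 log units; within the scatter) and stays within the scatter. For compound 4 the estimated clearance is 8 mL/min/kg, with an expected range from 4 mL/min/kg to 16 mL/min/kg.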

Compound 4, clearance: 2 mL/min/kg
For compound 4 the middle estimate is 4.0-fold (0.60 log units) above the measured one; the measured number lies below the stated range.
By their numbers in this assay, from the lowest: compound 4; then compounds 2, 1 and 3 (each within the scatter of the next).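

In this assay, for the compounds shown here, the change on the sulfonyl sulfur gives a 3.5-fold lower number from compound 3 to compound 4 (0.54 log units; beyond the scatter) and is the only step here beyond the scatter, so this position can shift the number, and (4-hydroxycyclohexyl)amino is one group that does so. Nothing measured here explains the step. Still open, as far as these compounds go, is which part of the entering group matters: the ring, the hydroxyl or the nitrogen attached to the sulfur. A plain cyclohexylamino group or a morpholine on the same sulfur would help separate these parts.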